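The source may hold more compounds than are shown below. What is called first, only, known or untested is meant among the compounds shown, and "the series" means these compounds.

The measured compounds:

Compound 1 `c1ccc(-c2cn3ccnc3c(-c3ccc4ncn(C5CCCCC5)c4c3)n2)cc1` gives 29.3% in a functional assay on DU-145 cells (Homo sapiens) for inhibition, read by sulforhodamine B assay, with a stated time of 48 h, tested at 10 uM; on this read-out lower numbers stand for less inhibition and higher numbers for more inhibition at the one concentration tested (going by the name of the read-out).
Compound 2 `COc1ccc(-c2cn3ccnc3c(-c3ccc4ncn(C5CCCCC5)c4c3)n2)cc1` gives 81.8% in this assay.
Compound 3 `O=Cc1ccc(-c2cn3ccnc3c(-c3ccc4ncn(C5CCCCC5)c4c3)n2)cc1` gives 24.3% in this assay.

Compound 3 stands lowest of the three numbers. Its nearest neighbour is compound 1, and the step of a number 5 percentage points lower from compound 1 to compound 3 (within the scatter) lies within the scatter, so the two cannot be told apart. The step of a number 57.5 percentage points lower from compound 2 to compound 3 (beyond the scatter) is large, as is a number 52.5 percentage points higher from compound 1 to compound 2 (beyond the scatter): the methoxy group stands out, while hydrogen and formyl sit together at the low end.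

Compound 4 `c1ccc2c(-c3cn4ccnc4c(-c4ccc5ncn(C6CCCCC6)c5c4)n3)cccc2c1` differs from compound 3 at one site: naphthalen-1-yl in place of 4-formylphenyl on an aromatic carbon. The entering group, like hydrogen in compound 1, carries no hydrogen-bond acceptor, and compound 1 in this assay gives 29.3%, close to compound 3. Among the compounds with values here, no measured step involves a second fused ring, so the bearing of the measured steps is indirect. The expectation is therefore a step of a number 10.7 percentage points higher from compound 3 to compound 4 (beyond the scatter) of modest size, not clearly beyond the scatter. Compound 4 is estimated at 35%, within 15% to 65%.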

Compound 4, a percentage reported as inhibition, at one concentration (the size of the read-out at that concentration, not a potency): 5.1%
Compound 4: the middle estimate sits 29.9 percentage points above what was measured; measured number outside the range, below it.
By their numbers in this assay, from the lowest: compound 4; then compounds 3 and 1 (each within the scatter of the next); then compound 2.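

Naphthalen-1-yl takes the number below the level that compounds 1 and 3 share, with a number 24.2 percentage points lower from compound 1 to compound 4 (beyond the scatter) and a number 19.2 percentage points lower from compound 3 to compound 4 (beyond the scatter) in this assay, so that level was not the bottom of the range at this position. The same exchange, set against the methoxy-bearing ring, gives the widest step in the series, a number 76.7 percentage points lower from compound 2 to compound 4 (beyond the scatter), and shows that a second six-membered aromatic ring of carbon only does not match what the methoxy group gives here. Nothing at hand gives a reason for these falls.

The compounds shown leave open whether the high number of compound 2 is specific to methoxy or would also appear with a hydroxyl or an amine in its place. They also leave open how a longer ether chain would read here.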